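The source may hold more compounds than are shown below. What is called first, only, known or untested is meant among the compounds shown, and "the series" means these compounds.

Compound 1 `O=C(NNc1nncc2ccccc12)C1CC1c1ccc(OCC(F)(F)F)cc1` and compound 2 `CC(C)=CCC/C(C)=C/COc1ccc(C2CC2C(=O)NNc2nncc3ccccc23)cc1` share one core and differ only in the side chain on the aryl ether. In a functional assay on SK-MEL cells (Homo sapiens) for inhibition, read by MTT assay, with a stated time of 72 h (a lower number here means a stronger inhibitor, a higher number a weaker inhibitor), compound 2 gives 25000 nM and compound 1 gives 29000 nM; the step of a 1.2-fold higher number from compound 2 to compound 1 (0.06 log units; within the scatter) comes from the change (trifluoromethyl in place of 2,6-dimethylhepta-1,5-dien-1-yl on a saturated chain carbon bound to an oxygen on an aromatic ring).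

Compound 3 `CC(C)=CCC/C(C)=C/COc1ccc(C2CC2C(=O)NNC(=O)c2ccncc2)cc1` carries the same side chain as compound 2 on a different core; the cores differ by a group of 8 heavy atoms (6 carbon, 1 nitrogen, 1 oxygen; one six-membered aromatic ring with 1 hetero atom) in place of a group of 10 heavy atoms (8 carbon, 2 nitrogen; one six-membered aromatic ring of carbon only, one six-membered aromatic ring with 2 hetero atoms), on an amine nitrogen. In this assay compound 3 gives "not determined" (no result reported), so no number was obtained for it.

Compound 4 `O=C(NNC(=O)C1CC1c1ccc(OCC(F)(F)F)cc1)c1ccncc1` is related to compound 3 by trifluoromethyl in place of 2,6-dimethylhepta-1,5-dien-1-yl on a saturated chain carbon bound to an oxygen on an aromatic ring, the same change that links compound 2 to compound 1. Because compound 3 has no value, the expectation for compound 4 rests on compound 1, whose value is 29000 nM, and on compound 2 with 25000 nM. Compound 4 is therefore expected to give about 30000 nM in this assay, estimated between 8000 nM and 100000 nM.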

Compound 4, half-maximal inhibitory concentration: 81000 nM
For compound 4 the middle estimate is 2.7-fold (0.43 log units) below the measured one; the measured number falls inside the stated range.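

In this assay, for the compounds shown here, compound 3 has no number, so no step from it to compound 4 can be read. The compounds shown leave open how the side chain change acts on this core, and nothing shown bears on a cause.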